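The source may report more compounds than this note shows. Statements on the series, on what has been measured and on what is new or still open speak of the compounds shown alone.

The measured compounds are compound 1 `O=S(=O)(c1ccc(F)c(Cl)c1)c1cnc2cc(F)ccc2c1-c1ccc(Cl)cc1` with 0.45 mL/min, compound 2 `O=S(=O)(c1ccc(F)c(F)c1)c1cnc2cc(F)ccc2c1-c1ccc(Cl)cc1` with 1.41 mL/min, and compound 3 `O=S(=O)(c1ccc(F)cc1)c1cnc2ccc(Cl)cc2c1-c1ccc(Cl)cc1` with 0.2 mL/min, all in an ADME assay on microsomes from liver (Rattus norvegicus) for metabolic stability, tested at 2.5 uM; a higher number here means faster removal of the compound, a lower number slower removal.

Compound 1 and compound 2 differ in one place: fluoro in place of chloro on an aromatic carbon. This change made a 3.1-fold higher number from compound 1 to compound 2 (0.50 log units; beyond the scatter). Compound 3 differs from compound 1 in more than one place, and the difference between the two cores is not broken down here. In this assay compound 3 gives the lowest number of the three.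

Compound 4 `O=S(=O)(c1ccc(F)cc1)c1cnc2ccc(F)cc2c1-c1ccc(Cl)cc1` has not yet been measured. It differs from compound 3 by fluoro in place of chloro on an aromatic carbon. This is the same kind of change as that from compound 1 to compound 2, but its place is not the same: in compound 1 the chloro sits on a six-membered aromatic ring of carbon only, ortho to a fluoro group and meta to a large group, whereas in compound 3 it sits on a ring that is part of a fused or bridged system of two rings, meta to a fused ring and para to a fused ring. Because the earlier step of a 3.1-fold higher number from compound 1 to compound 2 (0.50 log units; beyond the scatter) gave a higher number, a step in the same direction but of uncertain size is expected for compound 4: a 2.0-fold higher number from compound 3 to compound 4 (0.30 log units; within the scatter). Compound 4 is therefore estimated at 0.4 mL/min in this assay, within 0.15 mL/min to 1 mL/min.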

Compound 4, intrinsic clearance in a liver preparation (reported as CLH), per the amount of preparation that the assay uses: 0.4 mL/min
Compound 4: middle estimate and measured number agree at the digits printed; measured number inside the range.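

In this assay, fluoro in place of chloro on an aromatic carbon gave a 2.0-fold higher number from compound 3 to compound 4 (0.30 log units; within the scatter). Set beside the earlier step on the core of compound 1, the size of the change carries over from one core to the other as far as these data can tell: the same change on two cores in this assay, a 3.1-fold higher number (0.50 log units; beyond the scatter) from compound 1 to compound 2 and a 2.0-fold higher number (0.30 log units; within the scatter) from compound 3 to compound 4, 1.6-fold (0.19 log units) apart, within the scatter of two such steps. This does not show that the change reliably raises the number on the core of compound 3, since that step alone cannot be told from the scatter, and two pairs, each with the halogen at a different place, say nothing of other cores or of why the numbers move.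

The compounds shown leave open what a nitrile, a methoxy group or an amine would do in place of the halogen at these two places. They also leave open whether the step would keep its size with a carboxylic acid or a longer chain elsewhere on these cores.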